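Swapping the pyrrolidine nitrogen substituent once more

A few compounds are considered here, and "the series" means these few. Any claim that something is new, unique, unknown or untested is made for them only; others in the source may bear on it.

Compound 1 `CN1CCN(c2ccc(Nc3ncc4nc(Nc5ccc(F)cc5)n([C@@H]5CCN(S(=O)(=O)C6CC6)C5)c4n3)cc2)CC1`: 2.5 nM
Compound 2 `CNC(=O)CN1CC[C@H](n2c(Nc3ccc(F)cc3)nc3cnc(Nc4ccc(N5CCN(C)CC5)cc4)nc32)C1`: 1520 nM

In a functional assay on HCC827 cells (Homo sapiens) for antiproliferative activity, read by MTT assay, with a stated time of 72 h (on this read-out higher numbers stand for weaker inhibition and lower numbers for stronger inhibition), compound 2 gives the highest of the two numbers; its nearest neighbour is compound 1, with a 610-fold higher number from compound 1 to compound 2 (2.78 log units; beyond the scatter). Compound 3 `CN1CCN(c2ccc(Nc3ncc4nc(Nc5ccc(F)cc5)n([C@H]5CCN(C(=O)CO)C5)c4n3)cc2)CC1` carries (hydroxymethyl)carbonyl in place of (methylcarbamoyl)methyl on an amine nitrogen in a ring. Among the measured compounds shown here, only that one step bears on this change, and it shows that the group on this nitrogen moves the number greatly. Because compound 3 leaves the group that gave compound 2 its 1520 nM, a large fall is expected, a 51-fold lower number from compound 2 to compound 3 (1.70 log units; beyond the scatter), though how far is uncertain. Compound 3 is therefore estimated at 30 nM, within 4 nM to 300 nM.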

Compound 3, half-maximal inhibitory concentration: 380 nM
Beside the measured number, compound 3's estimate is 13-fold (1.10 log units) below it; the measured number lies above the stated range.
By their numbers in this assay, from the lowest: compound 1; then compound 3; then compound 2.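

Replacing (methylcarbamoyl)methyl with (hydroxymethyl)carbonyl gives a 4.0-fold lower number from compound 2 to compound 3 (0.60 log units; beyond the scatter) and so recovers only a small part of the earlier loss. Compared with the 1-(cyclopropylsulfonyl)pyrrolidin-3-yl group, the 1-((hydroxymethyl)carbonyl)pyrrolidin-3-yl group still gives a 150-fold higher number from compound 1 to compound 3 (2.18 log units; beyond the scatter) and so shows that the large loss is not unique to compound 2. No available measurement explains these differences. Open, from the compounds shown here alone, is whether a methylsulfonyl or a plain acetyl group on this nitrogen would approach compound 1, and so whether the sulfonyl link or the cyclopropyl ring matters more.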